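The source may hold more compounds than are shown below. What is called first, only, known or untested is meant among the compounds shown, and "the series" means these compounds.

Compound 1, `Fc1ccccc1Cc1nc(-c2nc(C(F)(F)F)n[nH]2)c2ccccn12`: 17 10^-6 cm/s
Compound 2, `Cc1ncc(Cc2nc(-c3nc(C(F)(F)F)n[nH]3)n3ccccc23)cn1`: 27 10^-6 cm/s
Compound 3, `Cc1n[nH]c(-c2nc(Cc3ccccc3F)c3ccccn23)n1`: 1 10^-6 cm/s

Of the compounds shown here, three have so far been measured in an ADME assay on MDCKII-LE cells (Canis lupus familiaris) for permeability, in the apical to basolateral direction; a higher number here means that the compound crosses the layer faster, a lower number that the compound crosses the layer more slowly. Compound 3 stands lowest of the three: compound 1 lies well above it and compound 2 higher still, both gaps beyond the usual scatter. The next compound, compound 4, `Fc1ccccc1Cc1nc(-c2nc(C(F)F)n[nH]2)n2ccccc12`, differs from compound 3 in a single place: difluoromethyl in place of methyl on an aromatic carbon. Within the data shown here, no two measured compounds differ from each other in only one place, so there is no measured step that reads across directly. What the numbers do show is that compound 1, which carries a trifluoromethyl group on the same five-membered ring, gives 17 10^-6 cm/s, far above compound 3. On that basis compound 4 is expected to move upward from compound 3, though not necessarily all the way to compound 1. The expected step in this assay is a 7.0-fold higher number from compound 3 to compound 4 (0.85 log units; beyond the scatter). Compound 4 is estimated at 7 10^-6 cm/s, within a range from 2.5 10^-6 cm/s to 20 10^-6 cm/s.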

Compound 4, apparent permeability: 0.2 10^-6 cm/s
For compound 4 the middle estimate is 35-fold (1.54 log units) above the measured one; measured number below the stated range.
By their numbers in this assay, from the lowest: compound 4; then compound 3; then compounds 1 and 2 (each within the scatter of the next).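

In this assay, among these compounds, difluoromethyl in place of methyl on an aromatic carbon between two ring nitrogen atoms gives a 5.0-fold lower number from compound 3 to compound 4 (0.70 log units; beyond the scatter), the first step in this set that changes one place only. Putting fluorine on this group on the shared core of compound 3 and compound 4 therefore goes with a lower number, so the high numbers of compound 1 and compound 2, which carry trifluoromethyl but differ from compound 4 in more than one place, do not read across to this change. Nothing available explains why the number falls with this change.

On these data alone, how trifluoromethyl would behave on the core of compound 4 stays open. So does what an amine or a cyclopropyl ring at this position would give.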